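Swapping the amide aryl group for thiophene in a 5-HT1F series

The compounds below may be only part of what the source reports. "The series", "measured", "known", "first", "only" and "open" are said of these compounds alone.

Measured compounds:
Compound 1, `CCCCCC(=O)Nc1ccc2[nH]cc(C3CCN(C)CC3)c2n1`, gives 13 nM in an assay for binding affinity to 5-hydroxytryptamine receptor 1F (Homo sapiens), read by radioligand binding; on this read-out lower numbers stand for stronger inhibition and higher numbers for weaker inhibition.
Compound 2, `CN1CCC(c2c[nH]c3ccc(NC(=O)c4cccc(F)c4)nc23)CC1`, gives 11 nM in this assay.
Compound 3, `Cc1ccc(C(=O)Nc2ccc3[nH]cc(C4CCN(C)CC4)c3n2)cc1`, gives 12 nM in this assay.

The three compounds share one core and differ only in the group attached to the carbonyl carbon of the amide. Compound 3 stands with its number inside the scatter of both neighbours: the step of a 1.1-fold lower number from compound 1 to compound 3 (0.03 log units; within the scatter) and the step of a 1.1-fold higher number from compound 2 to compound 3 (0.04 log units; within the scatter) are each too small to count as a real change. The same holds for a 1.2-fold lower number from compound 1 to compound 2 (0.07 log units; within the scatter). Across these three, neither a straight pentyl chain nor two differently substituted phenyl rings on the carbonyl carbon moved the number beyond the scatter.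

Compound 4, `CN1CCC(c2c[nH]c3ccc(NC(=O)c4cccs4)nc23)CC1`, follows the same route: thiophen-2-yl in place of 4-methylphenyl on a carbonyl carbon. Because a 1.1-fold lower number from compound 1 to compound 3 (0.03 log units; within the scatter) and a 1.1-fold higher number from compound 2 to compound 3 (0.04 log units; within the scatter) at this position stayed within the scatter, the expectation is that the thiophene ring changes little, so the estimated step of no change at the digits printed from compound 3 to compound 4 (within the scatter) is not beyond the scatter. Compound 4 is therefore estimated at 12 nM, expected between 5 nM and 30 nM.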

Compound 4, inhibition constant: 7.1 nM
The estimate for compound 4 lay 1.7-fold (0.23 log units) above the measured number, within the range that was stated.
By their numbers in this assay, from the lowest: compounds 4, 2, 3 and 1 (each within the scatter of the next).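

The position on the carbonyl carbon, whose other neighbour is an amide-type nitrogen, now also accepts a five-membered aromatic ring with a sulfur atom: in this assay the thiophen-2-yl group of compound 4 stays within the scatter of all three earlier groups (a 1.7-fold lower number from compound 3 to compound 4 (0.23 log units; within the scatter)), (a 1.5-fold lower number from compound 2 to compound 4 (0.19 log units; within the scatter)) and (a 1.8-fold lower number from compound 1 to compound 4 (0.26 log units; within the scatter)). The earlier compounds shown here carried only a pentyl chain or a six-membered aromatic ring of carbon only here, so the range of groups that leave the number within the scatter now includes a ring with a hetero atom and a hydrogen-bond acceptor. Nothing given here explains why these four groups give such similar numbers.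

The compounds shown leave open whether a carboxylic acid or an amine on this carbonyl carbon would also stay within the scatter. They also leave open what a chain longer than pentyl would do.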